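The source may hold more compounds than are shown below. What is called first, only, known or untested is meant among the compounds shown, and "the series" means these compounds.

- Compound 1 `Oc1ccc(CN(Cc2ccccc2C(F)(F)F)Cc2ccc(O)c3ncccc23)c2cccnc12`: < 0.2 uM
- Compound 2 `Oc1ccc(CN(Cc2ccc(OC(F)(F)F)cc2)Cc2ccc(O)c3ncccc23)c2cccnc12`: "not determined" (no result reported)

In a functional assay on U-87MG ATCC cells (Homo sapiens) for antiproliferative activity, with a stated time of 3 days (on this read-out lower numbers stand for an effect already at smaller amounts and higher numbers for an effect only at larger amounts of compound), compound 1 gives < 0.2 uM, which is a limit and not a number. Compound 2 has no number to start from, as its result reads "not determined" (no result reported). Compound 3 `Oc1ccc(CN(Cc2cccs2)Cc2ccc(O)c3ncccc23)c2cccnc12` shares its core with both. The change is thiophen-2-yl in place of 4-(trifluoromethoxy)phenyl on a saturated chain carbon bound to an amine nitrogen. Within the data shown here, no measured step shows what this swap does, so no size or direction of step can be expected in this assay. Among the measured compounds shown here, the only guide is the limit of compound 1 < 0.2 uM. Compound 3 is expected near 0.2 uM, with an estimated range of 0.05 uM to 0.8 uM.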

Compound 3, concentration for half-maximal effect: < 0.2 uM
Compound 3: only a limit was reported (the forecaster's own chance of this, stated with the estimate: 45%); the middle value lies on the limit itself.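

No new step can be read from compound 1 to compound 3, since each result is a limit and not a number: the limit of < 0.2 uM in this assay, at which 2 of the 3 values shown sit. As far as these compounds go, what stays open is how far apart compound 1 and compound 3 really lie in this assay, and how compound 2 compares with either.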